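From 4-bromophenyl to 4-methylbenzyl on the aromatic nitrogen

A few compounds are considered here, and "the series" means these few. Any claim that something is new, unique, unknown or untested is made for them only; others in the source may bear on it.

In an ADME assay on C8166 cells (Homo sapiens) for cytotoxicity, read by MTT assay (a higher number here means that more compound is tolerated, a lower number that less compound is tolerated), compound 1 `CC(C)[C@@H](CO)n1cc(C(=O)O)c(=O)c2c(O)c(Cc3cccc(Cl)c3F)ccc21` gives 125000 nM, compound 2 `Cc1ccc(-n2cc(C(=O)O)c(=O)c3c(O)c(Cc4cccc(Cl)c4F)ccc32)cc1` gives 194000 nM and compound 3 `O=C(O)c1cn(-c2ccc(Br)cc2)c2ccc(Cc3cccc(Cl)c3F)c(O)c2c1=O` gives 85000 nM. The measured steps show a 1.5-fold lower number from compound 1 to compound 3 (0.17 log units; within the scatter) and a 2.3-fold lower number from compound 2 to compound 3 (0.36 log units; beyond the scatter), which leaves the bromo compound level with one neighbour and modestly under the other.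

Compound 4 `Cc1ccc(Cn2cc(C(=O)O)c(=O)c3c(O)c(Cc4cccc(Cl)c4F)ccc32)cc1` carries 4-methylbenzyl in place of 4-bromophenyl on an aromatic nitrogen. Going by the values given here, no measured step makes exactly this change. Among the compounds with values here, two steps bear on it. Within the data shown here, exchanging the whole group on that nitrogen moved little in a 1.6-fold higher number from compound 1 to compound 2 (0.19 log units; within the scatter), while the only step beyond the scatter is the modest bromo-for-methyl exchange, a 2.3-fold lower number from compound 2 to compound 3 (0.36 log units; beyond the scatter). Since the bromo leaves and a methyl-bearing group enters, a small rise in this assay is the likely direction, but nothing beyond the scatter is anticipated. The expected change is a 1.5-fold higher number from compound 3 to compound 4 (0.18 log units; within the scatter). Compound 4 is estimated at 130000 nM, with an expected range of 65000 nM to 260000 nM.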

Compound 4, half-maximal cytotoxic concentration: 256000 nM
Estimate against measurement, compound 4: 2.0-fold (0.29 log units) below; low and high end bracket the measured number.
By their numbers in this assay, from the lowest: compounds 3, 1, 2 and 4 (each within the scatter of the next, the first and the last beyond it).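

In this assay, exchanging the whole group on this aromatic nitrogen now moves the number beyond the scatter, which the earlier whole-group exchanges did not do: 4-methylbenzyl gives a 3.0-fold higher number from compound 3 to compound 4 (0.48 log units; beyond the scatter) against 4-bromophenyl and a 2.0-fold higher number from compound 1 to compound 4 (0.31 log units; beyond the scatter) against 1-(hydroxymethyl)-2-methylpropyl. Against 4-methylphenyl, however, it gives only a 1.3-fold higher number from compound 2 to compound 4 (0.12 log units; within the scatter) and so cannot be told apart from that group, which means the larger 4-methylbenzyl group is tolerated here without any clear change from its closest neighbour. Nothing in the data at hand explains these differences.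

The compounds shown leave open whether the difference from compound 3 follows the loss of the bromo or the change from phenyl to benzyl, which a 4-bromobenzyl group on this nitrogen would separate. They also leave open what a longer chain such as 2-phenylethyl, or an amine on the ring, would do in this assay at this position.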